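Imidazoline in place of pyrimidine on a chromane amine chain

The source may hold more compounds than are shown below. What is called first, only, known or untested is meant among the compounds shown, and "the series" means these compounds.

Compound 1, `c1cnc(NCCNCC2CCc3ccccc3O2)nc1`: 31.6 nM
Compound 2, `c1cnc(NCCCNCC2CCc3ccccc3O2)nc1`: 1.59 nM

Both compounds were tested in an assay on isolated protein (Bos taurus) with 5-hydroxytryptamine receptor 1D (Homo sapiens) as the target; a higher number here means a weaker inhibitor, a lower number a stronger inhibitor. Within the data shown here, compound 2 gives the lower of the two numbers; compound 1 is the only neighbour, and it sits a long way above compound 2, well beyond the scatter. Compound 3, `c1ccc2c(c1)CCC(CNCCCNC1=NCCN1)O2`, has not been measured. It differs from compound 2 in one place: a group of 5 heavy atoms (3 carbon, 2 nitrogen; one five-membered non-aromatic ring with 2 hetero atoms) in place of a group of 6 heavy atoms (4 carbon, 2 nitrogen; one six-membered aromatic ring with 2 hetero atoms), on an amine nitrogen. Among the measured compounds shown here, no measured pair shows the effect of this exchange, so nothing in the data fixes its size or direction. The author expects the step in this assay from compound 2 to compound 3 to be modest, at most a little toward a weaker inhibitor, and possibly within the scatter, that is a 1.9-fold higher number from compound 2 to compound 3 (0.28 log units; within the scatter). Compound 3 is therefore estimated at 3 nM, with a plausible range from 0.5 nM to 20 nM.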

Compound 3, half-maximal inhibitory concentration: 6.31 nM
Estimate against measurement, compound 3: 2.1-fold (0.32 log units) below; low and high end bracket the measured number.
By their numbers in this assay, from the lowest: compound 2; then compound 3; then compound 1.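

On the amine nitrogen, the exchange of pyrimidin-2-yl for the five-membered non-aromatic ring has a cost that can be read in this assay: there is a 4.0-fold higher number from compound 2 to compound 3 (0.60 log units; beyond the scatter), so this position accepts the new ring but does not treat the two groups alike. Compared with the shorter-chain pyrimidine, the new ring on the longer chain still comes out ahead, with a 5.0-fold lower number from compound 1 to compound 3 (0.70 log units; beyond the scatter), a step in which the ring and the chain length change together. Nothing available explains the direction or size of either step.

As far as these compounds go, how the five-membered ring would behave on the shorter chain remains open, and so does the separate share of ring and chain in the second step. Also open, from the compounds shown here alone, is whether a pyridin-2-yl group or an open-chain guanidine on the amine nitrogen would stay closer to compound 2, and whether a longer chain would lower the number further.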